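Chloro Substitution Repeated on a Second Core

A few compounds are considered here, and "the series" means these few. Any claim that something is new, unique, unknown or untested is made for them only; others in the source may bear on it.

In a functional assay on HepG2 cells (Homo sapiens) for antiproliferative activity, read by CCK-8 assay, with a stated time of 72 h, tested at 2 uM (a lower number here means a weaker effect, a higher number a stronger effect of the compound at the concentration tested), compound 3 `Nc1ccccc1NC(=O)/C=C/c1ccc(Cn2cnc3c(Nc4ccccc4)nc(Cl)nc32)cc1` gives 16.4%, while compound 1 `Nc1ccccc1NC(=O)/C=C/c1ccc(Cn2cnc3c(Nc4cccc(Cl)c4)nc(Cl)nc32)cc1` gives 35.8%. The step of a number 19.4 percentage points higher from compound 3 to compound 1 (beyond the scatter) arises from chloro in place of hydrogen on an aromatic carbon. Compound 2 `CCCCn1cnc2c(Nc3ccccc3)nc(NCOCc3ccc(C(=O)Nc4ccccc4N)cc3)nc21`, built on a different core, gives 46.6% in this assay and stands highest of the three measured compounds; the difference between its core and that of compound 3 is not broken down here. Compound 4 `CCCCn1cnc2c(Nc3cccc(Cl)c3)nc(NCOCc3ccc(C(=O)Nc4ccccc4N)cc3)nc21` differs from compound 2 by chloro in place of hydrogen on an aromatic carbon, the same change at the same place as that between compound 3 and compound 1. A step of a number 11.4 percentage points higher from compound 2 to compound 4 (beyond the scatter) is expected here, set beside a number 19.4 percentage points higher from compound 3 to compound 1 (beyond the scatter), resting on that single measured pair and tempered by the already high starting value of compound 2. Compound 4 is thus estimated at 58%, expected between 44% and 72%.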

Compound 4, a percentage reported as inhibition, at one concentration (the size of the read-out at that concentration, not a potency): 30.6%
Compound 4: the middle estimate sits 27.4 percentage points above what was measured, and the stated range ends above it.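

On the core of compound 2, the change from anilino to (3-chlorophenyl)amino gives a number 16 percentage points lower from compound 2 to compound 4 (beyond the scatter) in this assay. The effect of this change therefore does not carry from one core to the other in this series, as its direction reverses: the same change on two cores in this assay, a number 19.4 percentage points higher (beyond the scatter) from compound 3 to compound 1 and a number 16 percentage points lower (beyond the scatter) from compound 2 to compound 4, 35.4 percentage points apart, beyond the scatter of two such steps

This rests on a single pair for each core at one concentration, and it does not show which of the features that separate the two cores goes with the reversal, or how the change would behave on any further core. The compounds shown leave open whether fluoro, methyl or methoxy in place of the chloro would follow the direction seen on either core.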